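A few compounds are considered here, and "the series" means these few. Any claim that something is new, unique, unknown or untested is made for them only; others in the source may bear on it.

Measured compounds:
- compound 1 `COC(=O)c1cc(=O)c2c(OC)cc(OC)cc2n1C`: > 19000 nM
- compound 2 `COc1ccc(-c2cc(=O)c3c(OC)cc(OC)cc3n2S(=O)(=O)c2cccc([N+](=O)[O-])c2)cc1`: > 39600 nM

In a functional assay on HepG2 cells (Homo sapiens) for antiproliferative activity, with a stated time of 72 h (on this read-out higher numbers stand for an effect only at larger amounts of compound and lower numbers for an effect already at smaller amounts), compound 1 gives only a limit, > 19000 nM. In this assay compound 2 likewise gives only a limit, > 39600 nM. Among the measured compounds shown here, compound 2 thus stands at the limit of > 39600 nM in this assay, at which 1 of the 2 values shown sits, and the other value shown is also a limit, (the limit of > 19000 nM in this assay, at which 1 of the 2 values shown sits); no numerical value is available for either compound, and no step between measured compounds can be stated.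

Compound 3 `COc1ccc(-c2cc(=O)c3c(OC)cc(OC)cc3n2S(=O)(=O)c2ccc(Br)cc2)cc1` is not yet measured in this assay. It differs from compound 2 as follows: 4-bromophenyl in place of 3-nitrophenyl on a sulfonyl sulfur. With both measured compounds at limits, no direction of change can be derived from the data; the expectation is no effect beyond the scatter, most likely again a limit, since compound 2 sits at the limit of > 39600 nM in this assay, at which 1 of the 2 values shown sits.

For compound 3 the expected step is a step that the limit leaves unreadable from compound 2 to compound 3. Compound 3 is estimated in this assay at 40000 nM, within 10000 nM to 100000 nM.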

Compound 3, half-maximal effective concentration: 16300 nM
Beside the measured number, compound 3's estimate is 2.5-fold (0.39 log units) above it; low and high end bracket the measured number.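

In this assay, 4-bromophenyl in place of 3-nitrophenyl on a sulfonyl sulfur gives an at least 2.4-fold lower number from compound 2 to compound 3 (0.38 log units; beyond the scatter), so the group on this sulfur can move the read-out. Among the compounds shown here, compound 3 also gives the first value in this set that is a number rather than a limit, which gives later changes at this place a numerical reference. Compound 2 holds only a limit, so the step has a floor but no exact size: the limit of > 39600 nM in this assay, at which 1 of the 3 values shown sits.

The substituent and its place on the phenyl ring change together in this step, so the effect of bromine cannot be separated from that of its position. As far as these compounds go, it also remains open how a plain phenyl, an amine or a carboxylic acid on that ring, or a methyl directly on the sulfonyl sulfur would read out.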